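The compounds below may be only part of what the source reports. "The series", "measured", "known", "first", "only" and "open" are said of these compounds alone.

Measured so far:
Compound 1, `COc1ccnc(Nc2cc3[nH]c(-c4cccc(C(F)(F)F)c4)nc3cn2)c1`: 71%
Compound 2, `Fc1cnc(Nc2cc3[nH]c(-c4cccc(C(F)(F)F)c4)nc3cn2)c(F)c1`: 43%

In an ADME assay on microsomes from liver (Rattus norvegicus) for metabolic stability, read by LC-MS, with a stated time of 30 min, tested at 0.1 uM (a higher number here means that more of the compound is left, a lower number that less of the compound is left), compound 1 gives 71% while compound 2 gives 43%. Among the measured compounds shown here, of the two numbers, compound 2 holds the lower one: the single measured step, a number 28 percentage points lower from compound 1 to compound 2 (beyond the scatter), puts a 4-methoxypyridin-2-yl ring against a 3,5-difluoropyridin-2-yl ring on the same nitrogen of the shared core.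

Compound 3, `N#Cc1ccc(Nc2cc3[nH]c(-c4cccc(C(F)(F)F)c4)nc3cn2)nc1`, has not yet been measured in this assay. It differs from compound 2 by 5-cyanopyridin-2-yl in place of 3,5-difluoropyridin-2-yl on a nitrogen on an aromatic ring. The step from compound 1 to compound 2 is the only one that bears on this change, since it also swaps the ring on that nitrogen, and it was modest in size. For the measured compounds named here, no measured pair, however, replaces two fluorines with a nitrile, so the direction for compound 3 is open.

Compound 3 is therefore expected to sit near compound 2, with an expected step of a number 7 percentage points higher from compound 2 to compound 3 (within the scatter), which would not go beyond the scatter. The estimate for compound 3 in this assay is 50%, with a range from 25% to 75%.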

Compound 3, percent of the compound remaining: 49%
Compound 3: the middle estimate sits 1 percentage points above what was measured, within the range that was stated.
By their numbers in this assay, from the lowest: compounds 2 and 3 (each within the scatter of the next); then compound 1.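

In this assay, swapping the ring on this nitrogen gives a number 6 percentage points higher from compound 2 to compound 3 (within the scatter), so a 5-cyanopyridin-2-yl ring and a 3,5-difluoropyridin-2-yl ring cannot be told apart here, even though one carries a nitrile and the other two fluorines. Among the compounds shown here, the earlier result set the 4-methoxypyridin-2-yl ring apart from only one other ring, and a number 22 percentage points lower from compound 1 to compound 3 (beyond the scatter) now sets it apart from a second, differently substituted one. Among these three compounds, then, the gap belongs to compound 1 alone, and it does not depend on which of the other two rings is the partner in the comparison. No accompanying measurement explains why the ring of compound 1 stands apart from the other two.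

The compounds shown leave open whether the methoxy group itself matters or whether the fluorines and the nitrile simply do the same thing, a question that a bare pyridin-2-yl ring would help to settle. They also leave open whether a longer ether such as ethoxy, or an amine such as dimethylamino, in place of the methoxy group would stay near compound 1 or fall to the level of compound 2 and compound 3.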